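This account rests on a few compounds, and the source may have more. Where it says the series, first, only, none or still open, it means among the compounds named here.

Of the compounds shown here, three sharing one core have been tested in an ADME assay on L6 cells (Rattus norvegicus) for cytotoxicity, read by resazurin assay, with a stated time of 72 h; a higher number here means a weaker inhibitor, a lower number a stronger inhibitor. Compound 1 `OC(c1ccc(Cl)cc1)(c1cccnc1)c1ccccc1Cl` gives 61300 nM, and compound 3 `CC(C)Oc1ccccc1C(O)(c1ccc(Cl)cc1)c1cccnc1` gives 48300 nM. Compound 2 `OC(c1ccc(Cl)cc1)(c1cccnc1)c1ccccc1F` gives > 100000 nM, which is a limit of the assay and not a number. For compound 2 this reading is the limit of > 100000 nM in this assay, at which 1 of the 3 values shown sits.

Compound 4 `OC(c1ccc(Cl)cc1)(c1cccnc1)c1ccc(Cl)cc1F` keeps the fluoro group of compound 2 and differs from it by chloro in place of hydrogen on an aromatic carbon, meta to a fluoro group and para to a large group: chloro in place of hydrogen on an aromatic carbon.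

Within the data shown here, no measured step shows this exact change, so the closest evidence comes from swaps of one group on an aromatic carbon. Fluoro in place of chloro gives an at least 1.6-fold higher number from compound 1 to compound 2 (0.21 log units; that floor lies within the scatter), and isopropoxy in place of fluoro gives an at least 2.0-fold lower number from compound 2 to compound 3 (0.31 log units; beyond the scatter). Isopropoxy in place of chloro gives a 1.3-fold lower number from compound 1 to compound 3 (0.10 log units; within the scatter), so the two compounds without fluoro stay within the scatter of each other. Both steps that involve compound 2 leave it on the higher side, so a modest move towards a lower number is expected in this assay, though a reading at the limit remains possible. The expected change is an at least 1.6-fold lower number from compound 2 to compound 4 (0.22 log units; that floor lies within the scatter). For compound 4 the estimated value is 60000 nM, with an expected range of 30000 nM to 110000 nM.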

Compound 4, half-maximal inhibitory concentration: 59400 nM
For compound 4 the middle estimate is 1.0-fold (0.00 log units) above the measured one, within the range that was stated.
By their numbers in this assay, from the lowest: compounds 3, 4 and 1 (each within the scatter of the next). At a limit, above all of these: compound 2.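

In this assay, chloro in place of hydrogen, on an aromatic carbon meta to a fluoro group and para to a large group, gives an at least 1.6-fold lower number from compound 2 to compound 4 (0.22 log units; that floor lies within the scatter). The earlier steps shown here swapped one group for another at a single place on the ring, whereas this one adds a group at a second place while the fluoro group stays, and it turns a reading at a limit into a measured number. Compound 2 remains a limit of the assay and not a number, so the size printed for this step is only a floor: the limit of > 100000 nM in this assay, at which 1 of the 4 values shown sits.

From the compounds shown here alone, what an amine, a carboxylic acid or a longer chain would do at this same aromatic carbon remains open, so it cannot be said whether the result is particular to chloro or would follow from other groups placed there. Also open, going by these compounds, is whether chloro at this place would give a similar step on the compounds carrying chloro or isopropoxy instead of the fluoro group, namely compound 1 and compound 3.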